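Variation of the terminal amide cap on a shared core

This account rests on a few compounds, and the source may have more. Where it says the series, first, only, none or still open, it means among the compounds named here.

Compound 1 `Cc1ccc(S(=O)(=O)N[C@@H](CC(=O)NC(C)(C)C)C(=O)NCCNC(=O)Nc2ccccc2)cc1` is the reference point. In an ADME assay on HepG2 cells (Homo sapiens) for cytotoxicity (a lower number here means that less compound is needed, a higher number that more compound is needed for the effect), compound 1 gives only a limit, > 11000 nM. Compound 2 `COc1cccc(C(=O)NCCNC(=O)[C@H](CC(=O)NC(C)(C)C)NS(=O)(=O)c2ccc(C)cc2)c1` likewise reports a limit in this assay, > 11000 nM. Compound 3 `Cc1ccc(S(=O)(=O)N[C@@H](CC(=O)NC(C)(C)C)C(=O)NCCNC(=O)c2cc(C)ccc2F)cc1` also stops at a limit in this assay, > 11000 nM. The steps a step that the two limits leave unreadable from compound 1 to compound 2, a step that the two limits leave unreadable from compound 1 to compound 3 and a step that the two limits leave unreadable from compound 2 to compound 3 accordingly have no readable size; all three values share (the limit of > 11000 nM in this assay, at which 3 of the 3 values shown sit). Compound 4 `Cc1ccc(S(=O)(=O)N[C@@H](CC(=O)NC(C)(C)C)C(=O)NCCNC(=O)c2ccccn2)cc1` carries the change (pyridin-2-yl in place of anilino on a carbonyl carbon). Among the compounds with values here, no measured step bears on this exchange with a usable size, and nothing separates one cap from another in this assay. Compound 4 is expected to come out at 15000 nM, with a range from 5000 nM to 50000 nM. The expected step is a step that the limit leaves unreadable from compound 1 to compound 4, most likely again only a limit.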

Compound 4, half-maximal effective concentration: > 11000 nM
Compound 4 gave a limit, no number; the forecaster's own chance of this, stated with the estimate: 85%; the middle value lies beyond the limit too.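

Compound 4 also stops at a limit, so none of its steps from compound 1, compound 2 or compound 3 can be read, and all four compounds sit together: the limit of > 11000 nM in this assay, at which 4 of the 4 values shown sit.

On these data alone, whether these terminal caps differ at all in this assay stays open.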